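A few compounds are considered here, and "the series" means these few. Any claim that something is new, unique, unknown or untested is made for them only; others in the source may bear on it.

Of the compounds shown here, three built on one shared core have been measured in a functional assay on COLO 205 cells (Homo sapiens) for inhibition, read by sulforhodamine B assay; a higher number here means a weaker inhibitor of growth, a lower number a stronger inhibitor of growth. Compound 1 `CN(C)c1ccc(-c2ccc(-c3ccc(-c4nc5ccccc5[nH]4)cc3)cc2)cc1` gives 100000 nM in this assay. Compound 2 `Clc1cccc(-c2ccc(-c3ccc(-c4nc5ccccc5[nH]4)cc3)cc2)c1` gives 100000 nM. The change between these two is 3-chlorophenyl in place of 4-(dimethylamino)phenyl on an aromatic carbon, and the step it made is no change at the digits printed from compound 1 to compound 2 (within the scatter). Compound 3 `CN(C)c1ccc(-c2ccc(-c3ccc(-c4nc5c(O)cccc5[nH]4)cc3)cc2)cc1` carries a different core; the difference between the two cores is hydroxy in place of hydrogen on an aromatic carbon. In this assay compound 3 gives 6320 nM, and the step from the plain core is a 16-fold lower number from compound 1 to compound 3 (1.20 log units; beyond the scatter). Compound 3 thus stands lowest of the three measured numbers, with its steps to both compound 1 and compound 2 beyond the scatter.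

Compound 4 `Oc1cccc2[nH]c(-c3ccc(-c4ccc(-c5cccc(Cl)c5)cc4)cc3)nc12` has not yet been measured. Among the compounds with values here, it differs from compound 3 by 3-chlorophenyl in place of 4-(dimethylamino)phenyl on an aromatic carbon, the same change as the one between compound 1 and compound 2, at the same place. Within the data shown here, that earlier step, no change at the digits printed from compound 1 to compound 2 (within the scatter), is the only guide available to what the change does. In this assay the expected step is a 1.1-fold higher number from compound 3 to compound 4 (0.04 log units; within the scatter), resting on the step of no change at the digits printed from compound 1 to compound 2 (within the scatter), which stayed within the scatter. Compound 4 is accordingly estimated at 7000 nM, within a range from 2500 nM to 25000 nM. Whether the hydroxy core behaves toward this change as the plain core did remains to be seen once the measurement is in hand.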

Compound 4, concentration for 50% growth inhibition: 8600 nM
For compound 4 the middle estimate is 1.2-fold (0.09 log units) below the measured one; the range from low to high includes it.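

In this assay, within the data shown here, 3-chlorophenyl in place of 4-(dimethylamino)phenyl on the hydroxy core gives a 1.4-fold higher number from compound 3 to compound 4 (0.13 log units; within the scatter), and the two cores agree on this change: the same change on two cores in this assay, no change at the digits printed (within the scatter) from compound 1 to compound 2 and a 1.4-fold higher number (0.13 log units; within the scatter) from compound 3 to compound 4, 1.4-fold (0.13 log units) apart, within the scatter of two such steps Hydroxy in place of hydrogen gives a 12-fold lower number from compound 2 to compound 4 (1.07 log units; beyond the scatter), and its size holds with either of the two groups on the aromatic carbon: the same change on two cores in this assay, a 16-fold lower number (1.20 log units; beyond the scatter) from compound 1 to compound 3 and a 12-fold lower number (1.07 log units; beyond the scatter) from compound 2 to compound 4, 1.4-fold (0.13 log units) apart, within the scatter of two such steps This agreement covers only one pair of groups on two cores in a single assay; it does not show that a change that moves the number on one core would carry over in the same way, and it does not say why the hydroxy group comes with a lower number.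

The compounds shown leave open whether a methoxy group or an amine in place of the hydroxy would keep the lower number. They also leave open what a carboxylic acid or a morpholine in place of the 3-chlorophenyl would do on the hydroxy core, and whether the change would then carry over from the plain core as it does here.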